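From an Indole to a Pyrimidine on the Ring Nitrogen

A few compounds are considered here, and "the series" means these few. Any claim that something is new, unique, unknown or untested is made for them only; others in the source may bear on it.

Of the compounds shown here, three sharing one core have been measured in a functional assay on DU-145 cells (Homo sapiens) for inhibition, read by sulforhodamine B assay, with a stated time of 48 h; on this read-out higher numbers stand for weaker inhibition and lower numbers for stronger inhibition. Compound 1 `CO[C@@H]1CC=C2NN(c3cc(F)cc(Cl)c3)C(=O)C[C@]2(c2ccccc2)O1` gives 16100 nM, compound 2 `CO[C@@H]1CC=C2NN(c3cc4ccccc4[nH]3)C(=O)C[C@]2(C)O1` gives 14400 nM, and compound 3 `CO[C@@H]1CC=C2NN(c3cc4ccccc4[nH]3)C(=O)C[C@]2(c2ccccc2)O1` gives 7900 nM, the lowest of the three numbers, though its step from compound 2 lies within the scatter. Compound 4 `CO[C@@H]1CC=C2NN(c3cncnc3)C(=O)C[C@]2(c2ccccc2)O1` differs from compound 3 by pyrimidin-5-yl in place of 1H-indol-2-yl on an amide-type nitrogen in a ring. For the measured compounds named here, only one measured step concerns the same amide-type nitrogen in a ring: a 2.0-fold lower number from compound 1 to compound 3 (0.31 log units; beyond the scatter), a modest change; the other, a 1.8-fold lower number from compound 2 to compound 3 (0.26 log units; within the scatter), concerns the phenyl group. Exchanging the aryl group on that nitrogen has so far shifted the number only modestly, so a small move toward weaker inhibition is expected for compound 4, a 1.9-fold higher number from compound 3 to compound 4 (0.28 log units; within the scatter). Compound 4 is therefore estimated at 15000 nM, within a range of 6000 nM to 40000 nM.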

Compound 4, half-maximal inhibitory concentration: 7330 nM
Compound 4: the middle estimate sits 2.0-fold (0.31 log units) above what was measured, and the stated range covers the measured number.
By their numbers in this assay, from the lowest: compounds 4, 3, 2 and 1 (each within the scatter of the next, the first and the last beyond it).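

In this assay, pyrimidin-5-yl on the amide-type nitrogen gives a 1.1-fold lower number from compound 3 to compound 4 (0.03 log units; within the scatter), so 1H-indol-2-yl and its hydrogen-bond donor can give way to a smaller group without a clear change in the number. Replacing 3-chloro-5-fluorophenyl at the same place gives a 2.2-fold lower number from compound 1 to compound 4 (0.34 log units; beyond the scatter), so this smaller group also holds up against a halogen-bearing ring. No measurement here explains these results.

On these data alone, it remains open whether a longer chain ending in an amine or a carboxylic acid would change the number on this nitrogen. As far as these compounds go, the effect of pyrimidin-5-yl alongside methyl instead of phenyl on the saturated ring carbon also remains open.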